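The source may report more compounds than this note shows. Statements on the series, on what has been measured and on what is new or still open speak of the compounds shown alone.

The measured compounds are:
compound 1, `OC(CCn1nc2c(Br)c(Br)c(Br)c(Br)c2n1)c1cccc(Br)c1`, 123%
compound 2, `COc1cccc(C(O)CCn2nc3c(Br)c(Br)c(Br)c(Br)c3n2)c1`, 106%
compound 3, `C[C@H](O)CCn1nc2c(Br)c(Br)c(Br)c(Br)c2n1`, 112%

In a functional assay on CCRF-CEM cells (Homo sapiens) for antiproliferative activity, read by MTT assay, with a stated time of 24 h, tested at 25 uM (a higher number here means a weaker effect of the compound at the concentration tested, a lower number a stronger effect), compound 3 gives 112%, the second highest of the three numbers. Its nearest neighbour is compound 2 at 106%, within the scatter, and the furthest is compound 1 at 123%, beyond the scatter. Going by the values given here, the only step between measured compounds is a number 17 percentage points lower from compound 1 to compound 2 (beyond the scatter), a methoxy in place of bromo on an aromatic carbon; it does not bear on the change now followed. Compound 4, `CC(O)CCn1nc2c(Br)c(Br)c(Br)c(Br)c2n1`, differs from compound 3 as follows: the two compounds have the same atoms and bonds; at least one stereo element is drawn with a configuration in one of them and without one in the other: 1 of 1 stereo elements differ; a stereocentre at a saturated chain carbon is drawn S in compound 3 and without a configuration in compound 4. Among the compounds with values here, no measured step concerns a stereocentre drawn with or without a configuration, so no step beyond the scatter in this assay is expected. Compound 4 is therefore estimated at 112%, between 100% and 124%. The expected step, no change at the digits printed from compound 3 to compound 4 (within the scatter), lies within the scatter.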

Compound 4, a percentage reported as activity, at one concentration (the size of the read-out at that concentration, not a potency): 113%
Compound 4: middle estimate off by 1 percentage points, on the low side; the measured number falls inside the stated range.
By their numbers in this assay, from the lowest: compounds 2, 3, 4 and 1 (each within the scatter of the next, the first and the last beyond it).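

In this assay, going by these compounds alone, the first reading on the stereocentre is a number 1 percentage points higher from compound 3 to compound 4 (within the scatter), so the drawn configuration at this saturated chain carbon shows no effect beyond the scatter. The comparison rests on one structural difference: the fact that one of compounds 3 and 4 is drawn with a defined configuration and the other without, at the place where they differ. At the same carbon, methyl in place of 3-methoxyphenyl gives a number 7 percentage points higher from compound 2 to compound 4 (within the scatter), and methyl in place of 3-bromophenyl gives a number 10 percentage points lower from compound 1 to compound 4 (within the scatter), so neither aryl group stands apart from methyl here. Still open, as far as these compounds go, is how an amine or a carboxylic acid on that chain would read, and a longer chain likewise.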